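A few compounds are considered here, and "the series" means these few. Any claim that something is new, unique, unknown or untested is made for them only; others in the source may bear on it.

In a functional assay on SW1573 cells (Homo sapiens) for antiproliferative activity, read by sulforhodamine B assay, with a stated time of 48 h (a lower number here means a stronger inhibitor of growth, a higher number a weaker inhibitor of growth), compound 1 (`CCC(C#CC(=O)OC)O/C=C/C(=O)OC`) gives 540 nM and compound 2 (`CCCC(C#CC(=O)OC)O/C=C/C(=O)OC`) gives 320 nM while compound 3 (`COC(=O)C#CC(CC(C)C)O/C=C/C(=O)OC`) gives 380 nM on the same shared core. Compound 3 thus stands within the scatter of both other compounds. Compound 4 (`COC(=O)C#CC(O/C=C/C(=O)OC)C(C)(C)C`) has not yet been measured and differs from compound 3 by tert-butyl in place of isobutyl on a saturated chain carbon bound to an oxygen on an unsaturated carbon and a triple-bonded carbon with the same atoms joined differently. Among the measured compounds shown here, three measured steps bear on this change: a 1.4-fold lower number from compound 1 to compound 3 (0.15 log units; within the scatter) and a 1.2-fold higher number from compound 2 to compound 3 (0.07 log units; within the scatter) and also a 1.7-fold lower number from compound 1 to compound 2 (0.23 log units; within the scatter) as the chain on that carbon varies. For the measured compounds named here, all three stay small, yet no measured compound carries tert-butyl at this place, so the range must stay wide. As far as these compounds go, on the strength of those steps, no change beyond the scatter is expected in this assay and the direction stays open, with an estimated 1.1-fold higher number from compound 3 to compound 4 (0.02 log units; within the scatter) as the working figure. Compound 4 is therefore expected at 400 nM (estimated range 180 nM to 900 nM).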

Compound 4, concentration for 50% growth inhibition: 3000 nM
Estimate against measurement, compound 4: 7.5-fold (0.88 log units) below; measured number outside the range, above it.
By their numbers in this assay, from the lowest: compounds 2, 3 and 1 (each within the scatter of the next); then compound 4.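

In this assay the chain on the saturated carbon bound to an oxygen on an unsaturated carbon and a triple-bonded carbon is not freely interchangeable: ethyl, propyl and isobutyl stand within the scatter of one another, but tert-butyl stands apart, with a 7.9-fold higher number from compound 3 to compound 4 (0.90 log units; beyond the scatter) and a 9.4-fold higher number from compound 2 to compound 4 (0.97 log units; beyond the scatter) and also a 5.6-fold higher number from compound 1 to compound 4 (0.74 log units; beyond the scatter) as steps beyond the scatter. Isobutyl and tert-butyl hold the same number of carbons, so the gap between compound 3 and compound 4 goes with how those atoms are joined, not with how many there are. Nothing measured here accounts for this difference.

The compounds shown leave open whether the rise in the number belongs to tert-butyl alone or would also appear with cyclohexyl at this place. They also leave open how a longer chain such as pentyl or a chain carrying an amine would behave there.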